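Replacing an aromatic amine with an ester side chain

A few compounds are considered here, and "the series" means these few. Any claim that something is new, unique, unknown or untested is made for them only; others in the source may bear on it.

Of the compounds shown here, three of one shared core have been tested in a functional assay on HeLa cells (Homo sapiens) for cytotoxicity, read by neutral red uptake, with a stated time of 3 days; on this read-out higher numbers stand for weaker inhibition and lower numbers for stronger inhibition. Compound 1 `C[S+]([O-])c1c(F)c(N)c2c(=O)cc(-c3ccc(N)c(F)c3)oc2c1F` reaches only the limit of this assay, giving > 100000 nM. Compound 2 `Nc1ccc(-c2cc(=O)c3c(N)c(F)c(O)c(F)c3o2)cc1F` likewise reaches only the limit, with > 100000 nM. Among the compounds with values here, compound 3 `Nc1ccc(-c2cc(=O)c3c(N)c(F)c(N)c(F)c3o2)cc1F` is the sole compound with a number, at 19000 nM, and so it stands as the strongest inhibitor of the set; both others sit at the limit of > 100000 nM in this assay, at which 2 of the 3 values shown sit.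

The steps toward compound 3 both point the same way: an at least 5.2-fold lower number from compound 1 to compound 3 (0.72 log units; beyond the scatter), and an at least 5.2-fold lower number from compound 2 to compound 3 (0.72 log units; beyond the scatter). In each case an amino group entering at this position lowered the number.

Compound 4 `CN(C)CC(=O)OCc1c(F)c(N)c2c(=O)cc(-c3ccc(N)c(F)c3)oc2c1F` differs from compound 3 by ((((dimethylamino)methyl)carbonyl)oxy)methyl in place of amino on an aromatic carbon. Since the amino group at this place is what separates compound 3 from the two limits, its removal in favour of a larger ester chain is expected to push the number back up, most likely toward or beyond the limit, giving a 4.2-fold higher number from compound 3 to compound 4 (0.62 log units; beyond the scatter). Compound 4 is therefore estimated at 80000 nM, within 20000 nM to 300000 nM.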

Compound 4, half-maximal inhibitory concentration: 9200 nM
Beside the measured number, compound 4's estimate is 8.7-fold (0.94 log units) above it; measured number outside the range, below it.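

An amino group is not required at this position for a low number in this assay: the ((((dimethylamino)methyl)carbonyl)oxy)methyl chain, a far larger group, gives a 2.1-fold lower number from compound 3 to compound 4 (0.31 log units; beyond the scatter). The same chain also gives an at least 10-fold lower number from compound 2 to compound 4 (1.03 log units; beyond the scatter), and an at least 10-fold lower number from compound 1 to compound 4 (1.03 log units; beyond the scatter), so among the groups shown here at this position, the chain goes with the lowest number. The values of compound 1 and compound 2 are limits rather than numbers, so these last two steps fix only a smallest size: the limit of > 100000 nM in this assay, at which 2 of the 4 values shown sit.

As far as these compounds go, whether the lower number goes with the ester, the dimethylamino end or the chain as a whole remains open. A hydroxymethyl group, or a chain ending in a carboxylic acid, in this place would help to separate these parts.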